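Swapping a methoxyphenyl for a fluorophenyl on the benzyl arm

A few compounds are considered here, and "the series" means these few. Any claim that something is new, unique, unknown or untested is made for them only; others in the source may bear on it.

Measured compounds:
- compound 1, `COc1ccc(Cc2nnc(NC(=O)/C(C#N)=C/c3ccccc3OS(=O)(=O)c3ccc(OC)cc3)s2)cc1`: 100%
- compound 2, `COc1ccc(Cc2nnc(NC(=O)/C(C#N)=C/c3ccccc3OS(=O)(=O)c3ccc(F)cc3)s2)cc1`: 25%

In a functional assay on HL-60 cells (Homo sapiens) for inhibition, read by CCK-8 assay, with a stated time of 48 h, tested at 20 uM (on this read-out higher numbers stand for more inhibition of growth at the one concentration tested and lower numbers for less inhibition of growth), compound 1 gives 100%. Among the compounds with values here, compound 2 gives 25%, the lowest of the two numbers known. Within the data shown here, the one measured step, a number 75 percentage points lower from compound 1 to compound 2 (beyond the scatter), came from a fluoro in place of methoxy on an aromatic carbon of the sulfonyl-bearing ring.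

Compound 3, `N#C/C(=C\c1ccccc1OS(=O)(=O)c1ccc(F)cc1)C(=O)Nc1nnc(Cc2cccc(F)c2)s1`, has not yet been measured. It differs from compound 2 by 3-fluorophenyl in place of 4-methoxyphenyl on a saturated chain carbon bound to an aromatic carbon. Among the measured compounds shown here, this change sits on a different part of the molecule from the one altered between compound 1 and compound 2, so no measured step bears directly on it; the earlier step only shows that exchanging methoxy for fluoro can matter a great deal. Compound 2 already lies low, leaving limited room for a further fall. The expected step is therefore a number 7 percentage points lower from compound 2 to compound 3 (within the scatter), a modest decrease or none beyond the scatter. The estimate for compound 3 is 18%, within a range from 3% to 40%.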

Compound 3, percent growth inhibition at one concentration: 22%
Compound 3: middle estimate off by 4 percentage points, on the low side; the range from low to high includes it.
By their numbers in this assay, from the lowest: compounds 3 and 2 (each within the scatter of the next); then compound 1.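

In this assay, exchanging 4-methoxybenzyl for 3-fluorobenzyl gives a number 3 percentage points lower from compound 2 to compound 3 (within the scatter), so this swap on the benzyl arm, which alters both the substituent and where it sits on the ring, leaves the growth-inhibition number within the usual scatter. Within the data shown here, that is a very different outcome from the only earlier step, a number 75 percentage points lower from compound 1 to compound 2 (beyond the scatter), which was made on the sulfonyl-bearing ring; in this small set, the large change belongs to that ring and not to the benzyl arm. The result applies only to compounds carrying fluoro on the sulfonyl-bearing ring, where the numbers are already low, and nothing available explains why the benzyl swap makes so little difference.

From the compounds shown here alone, it remains open whether the same swap would be just as quiet with the methoxy group of compound 1 on the sulfonyl-bearing ring, where there is far more inhibition to lose. Going by these compounds, it is also open how this position would respond to a group of a different kind, such as an amine or a carboxylic acid on the benzyl ring, or to a longer chain in place of the benzyl carbon.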